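This account rests on a few compounds, and the source may have more. Where it says the series, first, only, none or still open, it means among the compounds named here.

In a functional assay on NCI-H460 cells (Homo sapiens) for antiproliferative activity, read by MTT assay, with a stated time of 48 h (a higher number here means a weaker inhibitor, a lower number a stronger inhibitor), compound 3 `CCCCCC1(O)C(=O)Nc2ccc(Nc3ccc(C)cc3)cc21` gives > 100000 nM, which is a limit of the assay and not a number. Compound 1 `CCCCCCC1(O)C(=O)Nc2ccc(Nc3ccc(OC)cc3)cc21` gives > 100000 nM, which is also a limit. Compound 2 `CCCCC1(O)C(=O)Nc2ccc(Nc3ccc(C)cc3)cc21` gives a true number, 31800 nM. The picture so far is thus dominated by the limit of > 100000 nM in this assay, at which 2 of the 3 values shown sit.

Compound 4 `CCCCCCC1(O)C(=O)Nc2ccc(Nc3ccc(C)cc3)cc21` differs from compound 3 by a single change, methyl in place of hydrogen on a saturated chain carbon, five bonds along the chain from a saturated ring carbon. Among the compounds with values here, the one measured step of this kind is an at least 3.1-fold higher number from compound 2 to compound 3 (0.49 log units; beyond the scatter), where methyl replaced hydrogen on a saturated chain carbon, four bonds along the chain from a saturated ring carbon. That step lies beyond the scatter and points towards weaker inhibition. As far as these compounds go, since its end point is a limit, its full size is unknown. A further move in the same direction, or none beyond the scatter, is expected, and compound 4 will most likely also be reported only as a limit.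

The expected change is a step that the limit leaves unreadable from compound 3 to compound 4. The estimate for compound 4 is 120000 nM, with an expected range from 50000 nM to 300000 nM.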

Compound 4, half-maximal inhibitory concentration: > 100000 nM
Compound 4 was reported as a limit (the forecaster's own chance of this, stated with the estimate: 80%); the middle value does not contradict the limit.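

In this assay compound 4 gives > 100000 nM and this is a limit of the assay, not a number. The comparison with the shorter chain gives an at least 3.1-fold higher number from compound 2 to compound 4 (0.49 log units; beyond the scatter) and so keeps the loss already seen with compound 3, which shows that one further carbon on the chain does not bring back a readable value. The steps to compound 4 from compound 3 and from compound 1 cannot be read, since both ends of each are limits, and the series now gathers at one ceiling: the limit of > 100000 nM in this assay, at which 3 of the 4 values shown sit.

As far as these compounds go, how much weaker compound 3 and compound 4 really are therefore remains unknown. Also open, from the compounds shown here alone, is whether a propyl chain, or a chain carrying an amine or a carboxylic acid, would give a readable number on the shared core.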